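Amide Amine Exchange: An Expectation for Compound 3

A few compounds are considered here, and "the series" means these few. Any claim that something is new, unique, unknown or untested is made for them only; others in the source may bear on it.

compound 1: `CC1=C(C(C)C(=O)N(CCNC(C)C)C(C)C)c2cc(F)ccc2/C1=C\c1ccc([S+](C)[O-])cc1` — 15200 nM
compound 2: `CC1=C(C(C)C(=O)NCCN2CCCCC2)c2cc(F)ccc2/C1=C\c1ccc([S+](C)[O-])cc1` — 36300 nM

For the measured compounds named here, only two compounds have been run so far. In a functional assay on PC-3 cells (Homo sapiens) for inhibition, read by CellTiter-Glo, with a stated time of 72 h (a higher number here means that more compound is tolerated, a lower number that less compound is tolerated), compound 1 gives 15200 nM. In this assay compound 2 gives 36300 nM. Going by the values given here, compound 2 holds the higher of the two numbers; the single measured step, a 2.4-fold higher number from compound 1 to compound 2 (0.38 log units; beyond the scatter), is the only comparison that exists, and it comes from swapping one amine on the carbonyl carbon for another.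

Compound 3 `CC1=C(C(C)C(=O)N2CCN(CCCN(C)C)CC2)c2cc(F)ccc2/C1=C\c1ccc([S+](C)[O-])cc1` has not yet been measured. It differs from compound 2 in one place: 4-(3-(dimethylamino)propyl)piperazin-1-yl in place of (2-(piperidin-1-yl)ethyl)amino on a carbonyl carbon. Among the compounds with values here, this is again an exchange of the amine attached to the carbonyl carbon, so the step of a 2.4-fold higher number from compound 1 to compound 2 (0.38 log units; beyond the scatter) is the one measured step that bears on it, and that step was modest. With no other comparison to draw on, the expected step of a 1.2-fold lower number from compound 2 to compound 3 (0.08 log units; within the scatter) is small, and its direction is uncertain. The value of compound 3 in this assay is therefore expected to be about 30000 nM, within a range of 10000 nM to 90000 nM.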

Compound 3, half-maximal cytotoxic concentration: > 50000 nM
Compound 3: only a limit was reported; the forecaster's own chance of this, stated with the estimate: 10%; middle value at least 1.6-fold (0.22 log units) from the limit.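

In this assay compound 3 returns only a limit of the assay, not a number: the limit of > 50000 nM in this assay, at which 1 of the 3 values shown sits. Replacing isopropyl(2-(isopropylamino)ethyl)amino on the carbonyl carbon with 4-(3-(dimethylamino)propyl)piperazin-1-yl gives an at least 3.2-fold higher number from compound 1 to compound 3 (0.51 log units; beyond the scatter); the core of compound 1 carries no amide hydrogen and neither does that of compound 3, so the absence of that hydrogen does not by itself go with the lower number. Replacing (2-(piperidin-1-yl)ethyl)amino with the same piperazine group gives an at least 1.3-fold higher number from compound 2 to compound 3 (0.13 log units; that floor lies within the scatter), and that floor alone does not separate the two compounds, so the new group can be said to lie clear of compound 1 but not of compound 2.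

On these data alone, how far the true value of compound 3 lies past its limit stays open, and so does any ordering of the two highest compounds in this assay. As far as these compounds go, it is also open whether the piperazine ring or its 3-(dimethylamino)propyl chain carries the step, which a morpholine on the carbonyl carbon or a piperazine with a shorter 2-(dimethylamino)ethyl chain would begin to address.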